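Pyridinyl hydrazone on the triazine core: an expectation

The source may hold more compounds than are shown below. What is called first, only, known or untested is meant among the compounds shown, and "the series" means these compounds.

Compound 1 `NS(=O)(=O)c1ccc(Nc2nc(N/N=C/c3ccc(C(F)(F)F)cc3)nc(Nc3ccccc3)n2)cc1` is tested in a functional assay on MDA-MB-231 cells (Homo sapiens) for inhibition, read by sulforhodamine B assay, with a stated time of 48 h (a higher number here means that more compound is tolerated, a lower number that less compound is tolerated), where compound 1 gives 33700 nM. Compound 2 `Cc1nn(-c2ccccc2)cc1/C=N/Nc1nc(Nc2ccccc2)nc(Nc2ccc(S(N)(=O)=O)cc2)n1` carries a 3-methyl-1-phenyl-1H-pyrazol-4-yl group in place of the 4-(trifluoromethyl)phenyl group of compound 1, and in this assay compound 2 gives > 100000 nM, which is a limit of the assay rather than a number. Compound 2 thus sits at the limit of > 100000 nM in this assay, at which 1 of the 2 values shown sits. Among the compounds with values here, the one measured step, an at least 2.9-fold higher number from compound 1 to compound 2 (0.47 log units; beyond the scatter), shows that exchanging the aryl group on the carbon with a double bond to nitrogen can move the read-out beyond the scatter.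

Compound 3 `NS(=O)(=O)c1ccc(Nc2nc(N/N=C/c3ccccn3)nc(Nc3ccccc3)n2)cc1` differs from compound 2 by pyridin-2-yl in place of 3-methyl-1-phenyl-1H-pyrazol-4-yl on a carbon with a double bond to nitrogen. Within the data shown here, the only step that bears on this position is the one from compound 1 to compound 2, so the smaller pyridin-2-yl group is expected to return the read-out into the range of compound 1 or lower. Compound 3 is therefore estimated at 40000 nM, with a range from 12000 nM to 100000 nM. This estimate is expected to correspond to an at least 2.5-fold lower number from compound 2 to compound 3 (0.39 log units; beyond the scatter).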

Compound 3, concentration lethal to 50% of the cells: > 100000 nM
Compound 3 gave a limit, no number; the forecaster's own chance of this, stated with the estimate: 30%; middle value at least 2.5-fold (0.39 log units) away from the limit.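

Replacing 4-(trifluoromethyl)phenyl with pyridin-2-yl on a carbon with a double bond to nitrogen gives an at least 2.9-fold higher number from compound 1 to compound 3 (0.47 log units; beyond the scatter) in this assay, so the shift seen earlier is not tied to the larger 3-methyl-1-phenyl-1H-pyrazol-4-yl group, and a single aromatic ring with one hetero atom is enough for it to appear. Among the compounds shown, 4-(trifluoromethyl)phenyl is now the only group at this position that yields a number rather than a limit: the limit of > 100000 nM in this assay, at which 2 of the 3 values shown sit. The step between compound 2 and compound 3 cannot be read, as both values are limits, so pyridin-2-yl and 3-methyl-1-phenyl-1H-pyrazol-4-yl cannot be ranked against each other.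

What the compounds shown leave open is which part of 4-(trifluoromethyl)phenyl goes with the lower number, the trifluoromethyl group or the all-carbon ring that carries it. As far as these compounds go, it also remains open whether a plain phenyl group, or a phenyl group carrying an amine or a carboxylic acid in place of the trifluoromethyl, would give a number in this assay or another limit.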